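Swapping the acid head on a thiophene-linked biaryl

The source may hold more compounds than are shown below. What is called first, only, known or untested is meant among the compounds shown, and "the series" means these compounds.

Compound 1 `Cc1cccc(C)c1-c1cccc(OCc2cn(CCC(=O)O)nn2)c1` in a functional assay on cells for agonist activity at Free fatty acid receptor 1 (Homo sapiens), read by calcium flux (on this read-out higher numbers stand for an effect only at larger amounts of compound and lower numbers for an effect already at smaller amounts), gives 14700 nM. Compound 2 `Cc1cccc(C)c1-c1cccc(COc2ccc(CC3SC(=O)NC3=O)s2)c1` gives 82 nM in this assay, the lower of the two numbers and far apart from compound 1. Compound 3 `CCO[C@@H](CC(=O)O)c1ccc(OCc2cccc(-c3c(C)cccc3C)c2)s1` differs from compound 2 in one place: 2-carboxy-1-ethoxyethyl in place of (2,4-dioxo-1,3-thiazolidin-5-yl)methyl on an aromatic carbon. Among the measured compounds shown here, no measured pair shows this exact change, so its size cannot be read from the known numbers and rests on the head groups alone. Compound 3 is expected to stay near compound 2, with a step of a 1.4-fold lower number from compound 2 to compound 3 (0.14 log units; within the scatter) that may fall within the scatter. Compound 3 is estimated at 60 nM, within 12 nM to 300 nM.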

Compound 3, half-maximal effective concentration: 40100 nM
Beside the measured number, compound 3's estimate is 670-fold (2.82 log units) below it; measured number above the stated range.
By their numbers in this assay, from the lowest: compound 2; then compound 1; then compound 3.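

In this assay, 2-carboxy-1-ethoxyethyl in place of (2,4-dioxo-1,3-thiazolidin-5-yl)methyl gives a 490-fold higher number from compound 2 to compound 3 (2.69 log units; beyond the scatter) on this aromatic carbon, so the read-out depends strongly on which group sits here. Both groups count 8 heavy atoms, so that count alone does not set the result. No measurement here explains the step. Open, from the compounds shown here alone, is how a methoxy group in place of the ethoxy would read. Also open, going by these compounds, is how a tetrazole would read at this position, or the mirror-image form of compound 3.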